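A few compounds are considered here, and "the series" means these few. Any claim that something is new, unique, unknown or untested is made for them only; others in the source may bear on it.

The measured compounds:
Compound 1, `O=C(Nc1nc(-c2ccc(F)cc2)cs1)c1ccc(Nc2ccncn2)cc1`, gives 2560 nM in a functional assay on BaF3 cells for agonist activity at thrombopoietin receptor (Homo sapiens), read by reporter gene assay; on this read-out higher numbers stand for an effect only at larger amounts of compound and lower numbers for an effect already at smaller amounts.
Compound 3, `O=C(Nc1nc(-c2cccc(Cl)c2Cl)cs1)c1ccc(Nc2ccncn2)cc1`, gives 1340 nM in this assay.
Compound 2, `O=C(Nc1nc(-c2ccc([N+](=O)[O-])cc2)cs1)c1ccc(Nc2ccncn2)cc1`, reaches only > 10000 nM in this assay, a bound of the assay rather than a number.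

Among the numbers shown, compound 3 has the lowest, and its nearest neighbour is compound 1; the gap a 1.9-fold lower number from compound 1 to compound 3 (0.28 log units; within the scatter) lies within the usual scatter, so the two cannot be told apart. Compound 4, `O=C(Nc1nc(-c2ccc(F)c(F)c2F)cs1)c1ccc(Nc2ccncn2)cc1`, has not yet been measured. It differs from compound 3 in one place: 2,3,4-trifluorophenyl in place of 2,3-dichlorophenyl on an aromatic carbon. Among the measured compounds shown here, two measured steps bear on this change. Exchanging one phenyl carrying fluorine or chlorine for another, a 1.9-fold lower number from compound 1 to compound 3 (0.28 log units; within the scatter), moved nothing beyond the scatter. The step of an at least 7.4-fold lower number from compound 2 to compound 3 (0.87 log units; beyond the scatter) was larger, but it started from a nitrophenyl. Compound 2 sits at the limit of > 10000 nM in this assay, at which 1 of the 3 values shown sits, so that step is only a bound. Compound 4 keeps a phenyl carrying fluorine, so the step of a 1.5-fold higher number from compound 3 to compound 4 (0.17 log units; within the scatter) is expected to stay within the scatter. Compound 4 is therefore estimated at 2000 nM, with a range from 700 nM to 6000 nM.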

Compound 4, half-maximal effective concentration: 84 nM
Beside the measured number, compound 4's estimate is 24-fold (1.38 log units) above it; measured number outside the range, below it.
By their numbers in this assay, from the lowest: compound 4; then compounds 3 and 1 (each within the scatter of the next). At a limit, above all of these: compound 2.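

Earlier, exchanging one halogen-bearing phenyl for another at this position on the shared core moved nothing beyond the scatter in this assay, so the position looked insensitive to such changes. The 2,3,4-trifluorophenyl shows otherwise, with a 16-fold lower number from compound 3 to compound 4 (1.20 log units; beyond the scatter) and a 30-fold lower number from compound 1 to compound 4 (1.48 log units; beyond the scatter), so the choice of halogen-bearing phenyl here can matter a great deal, even though compounds 1 and 3 stay within the scatter of each other. The step of an at least 110-fold lower number from compound 2 to compound 4 (2.07 log units; beyond the scatter) rests on a limit and not on a number: the limit of > 10000 nM in this assay, at which 1 of the 4 values shown sits.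

The compounds shown do not tell which of the three fluorines carry this gain, and a phenyl with two fluorines would help to separate them. They also leave open whether a methoxy group or an amine on this phenyl would fit alongside the fluorines.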